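Cap variation on the shared core: propyl to phenyl

The source may report more compounds than this note shows. Statements on the series, on what has been measured and on what is new or still open speak of the compounds shown alone.

Measured so far in an assay on brain for displacement of a labelled ligand from Adrenergic receptor alpha-1 (Rattus norvegicus); a lower number here means a stronger inhibitor, a higher number a weaker inhibitor:

compound 1 `CCCNC(=O)N1CCN(c2cc(N)c3cc(OC)c(OC)cc3n2)CC1`: 0.44 nM
compound 2 `COc1cc2nc(N3CCN(C(=O)c4ccco4)CC3)cc(N)c2cc1OC`: 0.14 nM
compound 3 `COc1cc2nc(N3CCN(c4nccc(C)n4)CC3)cc(N)c2cc1OC`: 0.63 nM

Compound 1 holds the second highest of the three numbers. Its nearest neighbour is compound 3, with a 1.4-fold higher number from compound 1 to compound 3 (0.16 log units; within the scatter), a move that exchanges the whole propylcarbamoyl cap for a 4-methylpyrimidin-2-yl on the ring nitrogen. The furthest is compound 2, with a 3.1-fold lower number from compound 1 to compound 2 (0.50 log units; beyond the scatter), where a furan-2-yl replaces the propylamino on the carbonyl carbon. Between the two aromatic caps the gap is a 4.5-fold higher number from compound 2 to compound 3 (0.65 log units; beyond the scatter).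

Compound 4 `COc1cc2nc(N3CCN(C(=O)Nc4ccccc4)CC3)cc(N)c2cc1OC` keeps the carbonyl and the amide-type nitrogen of compound 1 and differs only there: phenyl in place of propyl on an amide-type nitrogen. Within the data shown here, no measured step touches this exact position. The two steps that bear on it both alter the same cap region: an aromatic group placed at the carbonyl carbon gave the lower number of compound 2, while a wholesale swap of the cap left compound 3 within the scatter of compound 1. The cap therefore appears tolerant, with a possible slight gain when an aromatic group enters. For compound 4 a step of a 1.3-fold lower number from compound 1 to compound 4 (0.10 log units; within the scatter) is expected, small and toward a lower number, likely within the scatter. The estimate for compound 4 in this assay is 0.35 nM, between 0.15 nM and 0.9 nM.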

Compound 4, inhibition constant: 0.34 nM
Compound 4: middle estimate off by 1.0-fold (0.01 log units), on the high side, and the stated range covers the measured number.
By their numbers in this assay, from the lowest: compound 2; then compounds 4, 1 and 3 (each within the scatter of the next).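

In this assay, among these compounds, phenyl in place of propyl on the amide-type nitrogen gives the first direct reading at this position (a 1.3-fold lower number from compound 1 to compound 4 (0.11 log units; within the scatter)): a six-membered aromatic ring of carbon can replace the propyl chain there, and compound 1 and compound 4 cannot be told apart. Compound 4 also cannot be told apart from compound 3 (a 1.9-fold lower number from compound 3 to compound 4 (0.27 log units; within the scatter)), but it remains separated from compound 2 (a 2.4-fold higher number from compound 2 to compound 4 (0.39 log units; beyond the scatter)), so an aromatic ring in the cap does not by itself reproduce the number of compound 2, and the direct exchange of anilino and furan-2-yl on the carbonyl carbon gives a modest step beyond the scatter. No evidence beyond these binding numbers bears on this result.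

Open, from the compounds shown here alone, is how far the tolerance at the amide-type nitrogen extends: a benzyl group, a longer chain such as hexyl, or a phenyl carrying a methoxy group or a chlorine could each test it. Also open, going by these compounds, is whether the number of compound 2 is specific to furan-2-yl, which thiophen-2-yl or phenyl on the same carbonyl carbon would help to settle.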